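Removing One Chloro From a Fused Dichloro Core

The source may hold more compounds than are shown below. What is called first, only, known or untested is meant among the compounds shown, and "the series" means these compounds.

Compound 2, `ClCc1ccccc1Cn1cnc2c(Cl)nc(Cl)nc21`: 4160 nM
Compound 1, `ClCc1ccc(Cn2cnc3c(Cl)ncnc32)cc1`: 2880 nM

Among the compounds with values here, in a functional assay on SF-268 cells (Homo sapiens) for cytotoxicity, read by sulforhodamine B assay, with a stated time of 48 h (a lower number here means a stronger inhibitor of growth, a higher number a weaker inhibitor of growth), compound 2 gives 4160 nM, the higher of the two numbers so far, yet compound 1 with 2880 nM lies within the scatter of it, so the two cannot be told apart. Compound 3, `ClCc1ccccc1Cn1cnc2c(Cl)ncnc21`, differs from compound 2 in one place: hydrogen in place of chloro on an aromatic carbon. Within the data shown here, no measured pair shows what this change does on its own. Both compound 1 and compound 3 carry hydrogen at that spot, and compound 1 gives 2880 nM, close to compound 2, which argues against a large shift. Only a step within the scatter is expected, namely a 1.2-fold lower number from compound 2 to compound 3 (0.08 log units; within the scatter). Compound 3 is therefore expected to give about 3500 nM in this assay, with a likely range from 1500 nM to 8000 nM.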

Compound 3, concentration for total growth inhibition: 10900 nM
Beside the measured number, compound 3's estimate is 3.1-fold (0.49 log units) below it, and the stated range ends below it.
By their numbers in this assay, from the lowest: compounds 1 and 2 (each within the scatter of the next); then compound 3.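

The change from chloro to hydrogen on the aromatic carbon between two ring nitrogen atoms now has a direct reading: in this assay it gives a 2.6-fold higher number from compound 2 to compound 3 (0.42 log units; beyond the scatter). This position therefore matters in this pair, with the chloro form the stronger inhibitor of growth, by a modest step that lies beyond the scatter. Nothing available explains the shift, so this remains an observation from a single pair of compounds.

On these data alone, it remains open whether chloro is special here, or whether another group at this spot, such as an amine, a methoxy group or fluoro, would give a number like that of compound 2. It is also unknown whether the same step would appear in a compound with the chloromethyl arrangement of compound 1.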